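Trimming the Ester Side Chain: From Compound 2 to Compound 3

The source may report more compounds than this note shows. Statements on the series, on what has been measured and on what is new or still open speak of the compounds shown alone.

Two measured compounds share one core and differ only in the side chain of one ester. Compound 1 `COC(=O)C1=C(C)NC(C)=C(C(=O)OCC(C)[N+](=O)[O-])C1c1cccc([N+](=O)[O-])c1` carries a 1-nitroethyl group there, and in a functional assay on HEK293 cells for antagonist activity at Voltage-dependent L-type calcium channel subunit alpha-1D (Rattus norvegicus), read by FLIPR (a higher number here means a weaker inhibitor, a lower number a stronger inhibitor), compound 1 gives 111 nM. Compound 2 `COC(=O)C1=C(C)NC(C)=C(C(=O)OCCCCc2ccc(OC)cc2)C1c1cccc([N+](=O)[O-])c1` carries a 3-(4-methoxyphenyl)propyl group instead, and in this assay compound 2 gives 38 nM. That single swap produced a 2.9-fold lower number from compound 1 to compound 2 (0.47 log units; beyond the scatter). Among the two numbers measured so far, compound 2 stands at the lowest, with compound 1 as its only neighbour, beyond the scatter.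

Compound 3 `COC(=O)C1=C(C)NC(C)=C(C(=O)OCCCOc2ccccc2)C1c1cccc([N+](=O)[O-])c1` keeps a chain on that ester but alters its far end: phenoxy in place of 4-methoxybenzyl on a saturated chain carbon, three bonds along the chain from an oxygen next to a carbonyl group. Going by the values given here, only the step from compound 1 to compound 2 touches the same chain, and it was modest, yet it swaps a quite different group, so it offers just a rough guide. Both compound 2 and compound 3 end the chain in an aromatic ring of carbon only, so a step within the scatter is expected, a 1.4-fold higher number from compound 2 to compound 3 (0.16 log units; within the scatter). Compound 3 is therefore expected to give 55 nM in this assay, within 20 nM to 150 nM.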

Compound 3, half-maximal inhibitory concentration: 11 nM
Estimate against measurement, compound 3: 5.0-fold (0.70 log units) above, outside the stated range (below it).
By their numbers in this assay, from the lowest: compound 3; then compound 2; then compound 1.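

Replacing 4-methoxybenzyl with phenoxy, on a saturated chain carbon three bonds along the chain from an oxygen next to a carbonyl group, gave a 3.5-fold lower number from compound 2 to compound 3 (0.54 log units; beyond the scatter) in this assay even though both groups hold one six-membered aromatic ring of carbon only and one hydrogen-bond acceptor. The far end of this ester chain therefore still moves the number when those counts stay the same, and the full change of side chain amounts to a 10-fold lower number from compound 1 to compound 3 (1.00 log units; beyond the scatter) across the compounds shown. No measurement offered here gives a reason for this difference.

The swap changes the link to the ring and removes the methoxy group in a single move, so the two changes cannot be told apart. A 4-methoxyphenoxy end on the same chain would separate them, and an amine at the chain end remains an open question.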